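From Fluoro to Benzyloxycarbonyl with Both Anchors at a Limit

The source may hold more compounds than are shown below. What is called first, only, known or untested is meant among the compounds shown, and "the series" means these compounds.

Compound 2, with the structure `Fc1ccc(-c2nn(-c3ccccc3)cc2-c2nc3cc(F)ccc3[nH]2)cc1`, was tested in an ADME assay on HaCaT cells (Homo sapiens) for cytotoxicity, read by MTT assay, with a stated time of 48 h; on this read-out higher numbers stand for weaker inhibition and lower numbers for stronger inhibition. In this assay compound 2 gives > 50000 nM, which is a limit of the assay rather than a number. Compound 1, with the structure `Fc1ccc2[nH]c(-c3cn(-c4ccccc4)nc3-c3ccccc3)nc2c1`, was measured alongside it. In this assay compound 1 gives > 50000 nM, again a limit. The step between them, a step that the two limits leave unreadable from compound 1 to compound 2, therefore cannot be read; all that the two results show is the limit of > 50000 nM in this assay, at which 2 of the 2 values shown sit.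

Compound 3, with the structure `O=C(OCc1ccccc1)c1ccc2[nH]c(-c3cn(-c4ccccc4)nc3-c3ccc(F)cc3)nc2c1`, has not yet been measured. It differs from compound 2 as follows: benzyloxycarbonyl in place of fluoro on an aromatic carbon. Going by the values given here, the only measured step is the unreadable one between compound 1 and compound 2, and it concerns a different change, so nothing measured speaks to the size or direction of the present step. Because the two results show (the limit of > 50000 nM in this assay, at which 2 of the 2 values shown sit), compound 3 is expected to sit at the limit as well, with an expected step of a number no higher from compound 2 to compound 3 (the limit leaves the size open). Compound 3 is therefore estimated at 50000 nM, with a range from 12000 nM to 200000 nM.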

Compound 3, half-maximal inhibitory concentration: > 50000 nM
Compound 3: a limit, no number (the forecaster's own chance of this, stated with the estimate: 65%); the middle value sits exactly at the limit.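

In this assay compound 3 gives > 50000 nM, which is a limit and not a number. Compound 2 also stands at a limit, so the step from compound 2 to compound 3 cannot be read. The compounds shown leave open how far each lies from that limit, and whether either change alters the result at all.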